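Pyridin-3-yl gives way to 4-(trifluoromethoxy)phenyl

The compounds below may be only part of what the source reports. "The series", "measured", "known", "first", "only" and "open" are said of these compounds alone.

In an ADME assay on J774 cells (Mus musculus) for antiproliferative activity, with a stated time of 72 h (a higher number here means that more compound is needed for the effect, a lower number that less compound is needed), compound 1 `CCCCc1cc2c(=O)cc(C)[nH]c2cc1OCCOc1ccccc1` gives 28000 nM, and compound 2 `CCCCc1cc2c(=O)c(-c3cccnc3)c(C)[nH]c2cc1OCCOc1ccccc1` gives 23000 nM. Among the measured compounds shown here, these two values lie within the scatter of each other, so compound 2 stands on a par with compound 1, the only other measured compound.

The next structure is compound 3 `CCCCc1cc2c(=O)c(-c3ccc(OC(F)(F)F)cc3)c(C)[nH]c2cc1OCCOc1ccccc1`, which differs from compound 2 at a single place: 4-(trifluoromethoxy)phenyl in place of pyridin-3-yl on an aromatic carbon. In words, 4-(trifluoromethoxy)phenyl stands in place of pyridin-3-yl on an aromatic carbon. For the measured compounds named here, only one measured step bears on this change, namely a 1.2-fold lower number from compound 1 to compound 2 (0.09 log units; within the scatter), where pyridin-3-yl took the place of hydrogen on that same aromatic carbon. Going by the values given here, it is small, but it is the only evidence at this carbon, and no measured compound carries 4-(trifluoromethoxy)phenyl. With so little to go on, no shift beyond the scatter is expected in this assay, and the estimated step is a 1.3-fold lower number from compound 2 to compound 3 (0.11 log units; within the scatter). For compound 3 the expected value is 18000 nM, with an estimated range from 6000 nM to 40000 nM.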

Compound 3, half-maximal effective concentration: 20000 nM
Estimate against measurement, compound 3: 1.1-fold (0.05 log units) below; low and high end bracket the measured number.
By their numbers in this assay, from the lowest: compounds 3, 2 and 1 (each within the scatter of the next).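

In this assay, the exchange of pyridin-3-yl (6 heavy atoms, with a ring nitrogen) for 4-(trifluoromethoxy)phenyl (11 heavy atoms, with oxygen and fluorine and a ring of carbon only) amounts to a 1.2-fold lower number from compound 2 to compound 3 (0.06 log units; within the scatter) and so leaves compound 3 on a par with compound 2, which shows that this aromatic carbon can carry the larger group without a step beyond the scatter. Measured against hydrogen on the same carbon, the new group gives a 1.4-fold lower number from compound 1 to compound 3 (0.15 log units; within the scatter) and thus adds a second, quite different ring to pyridin-3-yl, neither of which separates from hydrogen in this assay. No supporting measurement is available to explain why the three numbers stay so close.

Going by these compounds, it remains open whether any group on this carbon, such as an amine or a carboxylic acid, would give a step beyond the scatter. The three compounds also share the rest of the core of compound 1, so they say nothing about how a longer chain in place of the butyl group would read in this assay at all.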